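This account rests on a few compounds, and the source may have more. Where it says the series, first, only, none or still open, it means among the compounds named here.

Of the compounds shown here, three have numbers so far in a functional assay on MCF7 cells (Homo sapiens) for antiproliferative activity, read by sulforhodamine B assay, with a stated time of 3 days; on this read-out lower numbers stand for stronger inhibition and higher numbers for weaker inhibition. Compound 1 (`Fc1ccc(Sc2ncnc3[nH]cnc23)cc1`) gives 31600 nM, compound 2 (`Clc1ccc(Sc2ncnc3[nH]cnc23)c(Cl)c1`) gives 21400 nM, and compound 3 (`c1ccc2c(c1)COC(n1cnc3c(OCC4CCCCC4)ncnc31)CO2`) gives 11600 nM. The number for compound 3 is the lowest of the three, but its gap to compound 2 lies within the usual scatter of repeated measurements. Only its gap to compound 1 lies beyond that scatter.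

Compound 4 (`c1ccc(Sc2ncnc3c2ncn3C2COc3ccccc3CO2)cc1`) has phenylsulfanyl in place of the cyclohexylmethoxy of compound 3, on an aromatic carbon: phenylsulfanyl in place of cyclohexylmethoxy on an aromatic carbon. For the measured compounds named here, no measured pair isolates this swap, so the data offer no direct guide. Compound 1 at 31600 nM and compound 2 at 21400 nM also carry a sulfur-linked aromatic ring, but they lack the large group shared by compound 3 and compound 4, which makes them only a loose hint.

In this assay, no change beyond the scatter is expected, with a slight lean toward weaker inhibition. The expected step, a 1.1-fold higher number from compound 3 to compound 4 (0.05 log units; within the scatter), is therefore small and uncertain. For compound 4 the estimated value is 13000 nM, with an expected range from 4500 nM to 32000 nM.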

Compound 4, half-maximal inhibitory concentration: 7120 nM
Compound 4: middle estimate off by 1.8-fold (0.26 log units), on the high side, and the stated range covers the measured number.
By their numbers in this assay, from the lowest: compounds 4, 3, 2 and 1 (each within the scatter of the next, the first and the last beyond it).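

For the compounds shown here, the swap of cyclohexylmethoxy for phenylsulfanyl on this aromatic carbon, next to the ring nitrogen, gives a 1.6-fold lower number from compound 3 to compound 4 (0.21 log units; within the scatter) in this assay, and this is the first pair that tests a change at this position directly. A non-aromatic carbon ring joined through oxygen and an aromatic carbon ring joined through sulfur therefore cannot be told apart here, so in this pair the read-out does not separate the two groups, even though they differ in ring type and linking atom. No measured property of either group accompanies this pair, and nothing here accounts for the result.

Both groups at this position are of similar size and carry a six-membered ring, so a much smaller or very different group, such as a simple amine, a short methoxy or a carboxylic acid, remains an open test of how far this position can change. No pair among the compounds shown changes only the large group shared by compound 3 and compound 4, so its own part in these numbers also stays unknown.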